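Chain lengthening in two related cores: working notes

The compounds below may be only part of what the source reports. "The series", "measured", "known", "first", "only" and "open" are said of these compounds alone.

Compound 1 `CCCCCCCCCCCCOc1cc(OC)c(Br)cc1C(C)=O` and compound 2 `CCCCCCCCCCCCCCOc1cc(OC)c(Br)cc1C(C)=O` share one core. In a functional assay, with stated times of 30 s and 6 min, in the presence of a further agent that is not named here (on this read-out higher numbers stand for weaker inhibition and lower numbers for stronger inhibition), compound 1 gives 10600000 nM and compound 2 gives 6800000 nM. The change between them is ethyl in place of hydrogen on a saturated chain carbon, ten or more bonds along the chain from an oxygen on an aromatic ring, and it made a 1.6-fold lower number from compound 1 to compound 2 (0.19 log units; within the scatter), so the two values cannot be put in order.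

Compound 3 `CCCCCCCCCCOc1cc(OC)ccc1C(C)=O` carries a second core; how the two cores differ is not broken down here. In this assay, for the measured compounds named here, compound 3 gives 26600000 nM, the highest of the three numbers measured so far, with compound 1 nearest and compound 2 furthest from it.

Compound 4 `CCCCCCCCCCCCOc1cc(OC)ccc1C(C)=O` is not yet measured. It differs from compound 3 by ethyl in place of hydrogen on a saturated chain carbon, ten or more bonds along the chain from an oxygen on an aromatic ring, the same change, at the same place in the same words, as from compound 1 to compound 2. Only one earlier occurrence of this change is at hand, and it sits on the other core, so the expectation is loose.

Because the earlier step was a 1.6-fold lower number from compound 1 to compound 2 (0.19 log units; within the scatter), compound 4 is expected to stay close to compound 3, with a step of a 1.5-fold lower number from compound 3 to compound 4 (0.17 log units; within the scatter) expected. In this assay compound 4 is estimated at 18000000 nM. Going by the values given here, the estimate for compound 4 is expected to fall between 8000000 nM and 40000000 nM, a range that stays wide since the single earlier step lay within scatter and the numbers are all very high.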

Compound 4, half-maximal inhibitory concentration: 28500000 nM
Compound 4: the middle estimate sits 1.6-fold (0.20 log units) below what was measured; low and high end bracket the measured number.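

In this assay the new step, a 1.1-fold higher number from compound 3 to compound 4 (0.03 log units; within the scatter), stays within the scatter, just as the earlier step on the core of compound 1 did, so ethyl in place of hydrogen at this place on the chain gives no readable change on either core. Set side by side, the two steps do not differ: the same change on two cores in this assay, a 1.6-fold lower number (0.19 log units; within the scatter) from compound 1 to compound 2 and a 1.1-fold higher number (0.03 log units; within the scatter) from compound 3 to compound 4, 1.7-fold (0.22 log units) apart, within the scatter of two such steps This agreement supports only a limited statement: in these two pairs the change stays too small to read on both cores, which does not show that a step of real size would carry from one core to the other, and two pairs establish no rule for the series. The cores themselves are not equivalent in this read-out, since hydrogen in place of bromo on an aromatic carbon gives a 2.7-fold higher number from compound 1 to compound 4 (0.43 log units; beyond the scatter), a modest step.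

From the compounds shown here alone, that step rests on a single pair at one chain length, so whether it holds with other chains stays open. Also open, going by these compounds, is whether a longer chain, or an amine or a carboxylic acid in place of the ethyl, would give a step beyond the scatter on either core.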